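Removing the methoxy group from compound 2

The source may report more compounds than this note shows. Statements on the series, on what has been measured and on what is new or still open speak of the compounds shown alone.

Measured so far:
compound 1 `C=COc1cc(N2CCCNCCC2)cnc1Br`: 240 nM
compound 2 `COc1cc(N2CCNCC2)cnc1Br`: 17000 nM
compound 3 `c1cncc(N2CCCNCCC2)c1`: 36.3 nM

In a functional assay on HEK293 cells for agonist activity at Neuronal acetylcholine receptor; alpha4/beta2 (Homo sapiens), read by FLIPR and calcium flux (on this read-out higher numbers stand for an effect only at larger amounts of compound and lower numbers for an effect already at smaller amounts), compound 2 stands at the highest number of the three; compound 1 lies far below it and compound 3 lower still, both gaps beyond the usual scatter. Compound 4 `Brc1ccc(N2CCNCC2)cn1` differs from compound 2 in a single place: hydrogen in place of methoxy on an aromatic carbon. Among the compounds with values here, no measured pair differs in only this way, so the size of the step cannot be read from the data. A modest step toward a lower number is expected, a 3.4-fold lower number from compound 2 to compound 4 (0.53 log units; beyond the scatter), because compound 3, the smallest of the measured compounds, gives 36.3 nM. Compound 4 is therefore estimated at 5000 nM, with a likely range from 1500 nM to 20000 nM.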

Compound 4, half-maximal effective concentration: 2510 nM
Compound 4: middle estimate off by 2.0-fold (0.30 log units), on the high side; measured number inside the range.
By their numbers in this assay, from the lowest: compound 3; then compound 1; then compound 4; then compound 2.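

In this assay, hydrogen in place of methoxy on this aromatic carbon, ortho to the bromo group, gives a 6.8-fold lower number from compound 2 to compound 4 (0.83 log units; beyond the scatter). Within the data shown here, this is the first single-place change, and it shows that the methoxy group is not needed for the effect here: without it, the effect appears at smaller amounts of compound. Nothing available explains why this step occurs.

Going by these compounds, whether an amine or an ethoxy group on this carbon would give a number nearer that of compound 2 or compound 4 remains open. Also open, on these data alone, is whether a similar step would appear on the core of compound 1.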